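The compounds below may be only part of what the source reports. "The series", "measured", "known", "first", "only" and "open" are said of these compounds alone.

Notes on the series. Three analogues of the shared core have been measured in an in vitro ADME assay on microsomes from liver (Mus musculus) for pharmacokinetics, read by LC-MS, with a stated time of 10 min, tested at 1 uM (on this read-out higher numbers stand for fast clearance and lower numbers for slow clearance), and they differ from one another only at one aromatic carbon. Compound 1 `CN1C[C@H](C(=O)Nc2ccccc2)[C@@H](c2ccc(/C=C/C(=O)Nc3ccccc3N)cc2)C1` carries hydrogen there, and in this assay compound 1 gives 67 mL/min/kg. Compound 2 `Cc1ccc(NC(=O)[C@H]2CN(C)C[C@@H]2c2ccc(/C=C/C(=O)Nc3ccccc3N)cc2)cc1` carries methyl at that carbon, and in this assay compound 2 gives 62 mL/min/kg. Compound 3 `CN1C[C@H](C(=O)Nc2ccc(C3CC3)cc2)[C@@H](c2ccc(/C=C/C(=O)Nc3ccccc3N)cc2)C1` carries cyclopropyl, and in this assay compound 3 gives 60 mL/min/kg. Compound 2 stands second highest of the three numbers, with compound 3 nearest and compound 1 furthest; all three lie within the scatter of one another, as the steps show: a 1.1-fold lower number from compound 1 to compound 2 (0.03 log units; within the scatter), a 1.1-fold lower number from compound 1 to compound 3 (0.05 log units; within the scatter) and a 1.0-fold lower number from compound 2 to compound 3 (0.01 log units; within the scatter).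

Compound 4 `CN1C[C@H](C(=O)Nc2ccc(Br)cc2)[C@@H](c2ccc(/C=C/C(=O)Nc3ccccc3N)cc2)C1` is the next analogue. Its change from compound 2 is bromo in place of methyl on an aromatic carbon. The three measured steps all sit at this same aromatic carbon, and none of them moves clearance beyond the scatter, so for compound 4 no step beyond the scatter is expected in either direction. The estimated step is no change at the digits printed from compound 2 to compound 4 (within the scatter). In this assay compound 4 is therefore expected to give 62 mL/min/kg, with a range from 40 mL/min/kg to 95 mL/min/kg.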

Compound 4, clearance: 16 mL/min/kg
The estimate for compound 4 lay 3.9-fold (0.59 log units) above the measured number; the measured number lies below the stated range.
By their numbers in this assay, from the lowest: compound 4; then compounds 3, 2 and 1 (each within the scatter of the next).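

The position is less indifferent to substitution in this assay than hydrogen, methyl and cyclopropyl suggested, since those three stayed within the scatter of one another. Bromo is the only one of the four groups that sets a compound apart at this aromatic carbon, with a 3.9-fold lower number from compound 2 to compound 4 (0.59 log units; beyond the scatter) and a 3.8-fold lower number from compound 3 to compound 4 (0.57 log units; beyond the scatter) and a 4.2-fold lower number from compound 1 to compound 4 (0.62 log units; beyond the scatter) as the steps, all modest and all towards slower clearance. Nothing available bears on why bromo parts from the other three groups here.

On these data alone, whether the lower number belongs to bromo alone or extends to other halogens such as chloro or fluoro remains open. Also open, as far as these compounds go, is how a group of another kind at this carbon, such as an amine or a carboxylic acid, would read.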